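This account rests on a few compounds, and the source may have more. Where it says the series, first, only, none or still open, it means among the compounds named here.

Of the compounds shown here, three have been measured in an assay on a protein complex for binding affinity to Neuronal acetylcholine receptor; alpha4/beta2 (Homo sapiens); a higher number here means a weaker inhibitor, a lower number a stronger inhibitor; every value shown is a limit of the assay and not a number.

Compound 1, `COc1cccc(NC(=O)N[C@@H]2C3CCN(CC3)[C@@H]2Cc2cccnc2)c1`: > 10000 nM
Compound 2, `CSc1ccc(NC(=O)N[C@@H]2C3CCN(CC3)[C@@H]2Cc2cccnc2)cc1`: > 10000 nM
Compound 3, `O=C(Nc1ccc(Cl)c(Cl)c1)N[C@@H]1C2CCN(CC2)[C@@H]1Cc1cccnc1`: > 10000 nM

Compound 1 therefore stands only at a limit in this assay, and the two further values shown are limits as well; all three sit at the limit of > 10000 nM in this assay, at which 3 of the 3 values shown sit. The steps between them, a step that the two limits leave unreadable from compound 1 to compound 2, a step that the two limits leave unreadable from compound 1 to compound 3 and a step that the two limits leave unreadable from compound 2 to compound 3, cannot be read in size, as both ends of each step are limits. Compound 4, `O=C(Nc1cccc(C(F)(F)F)c1)N[C@@H]1C2CCN(CC2)[C@@H]1Cc1cccnc1`, has not yet been measured in this assay. It differs from compound 1 in one place: trifluoromethyl in place of methoxy on an aromatic carbon. Going by the values given here, all three measured steps alter the same ring on the amide-type nitrogen, and none has a readable size, so they set no direction for the step from compound 1 to compound 4 and no size beyond the scatter can be claimed. Because all three measured compounds sit at the limit of > 10000 nM in this assay, at which 3 of the 3 values shown sit, compound 4 is expected to sit at or near that limit too, and the step that the limit leaves unreadable from compound 1 to compound 4 is expected to be unreadable. The estimate for compound 4 in this assay is 15000 nM, in a range from 4000 nM to 60000 nM, with a strong chance that only a limit is reported again.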

Compound 4, inhibition constant: > 10000 nM
Compound 4 was reported as a limit; the forecaster's own chance of this, stated with the estimate: 85%; the middle value is on the limit's open side.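

In this assay compound 4 gives > 10000 nM, which is a limit and not a number. Compound 1 also stands at a limit, so the step between compound 1 and compound 4 cannot be read in size. The compounds shown leave open what any of their actual values is, since all stand at one limit: the limit of > 10000 nM in this assay, at which 4 of the 4 values shown sit.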